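Five-membered ring swaps on a shared core

The source may hold more compounds than are shown below. What is called first, only, known or untested is meant among the compounds shown, and "the series" means these compounds.

Compound 1 `Cn1nc2c(=O)n(CC3(O)CCN(Cc4ccc(-c5ccoc5)cc4Cl)CC3)cnc2c1-c1ccc(CN)cc1` gives 177 nM in an assay on isolated protein for inhibition of ubiquitin carboxyl-terminal hydrolase 7 (Homo sapiens), with stated times of 30 min and 2 h; a higher number here means a weaker inhibitor, a lower number a stronger inhibitor.
Compound 2 `Cn1nc2c(=O)n(CC3(O)CCN(Cc4ccc(-c5n[nH]c(=O)o5)cc4Cl)CC3)cnc2c1-c1ccc(CN)cc1` gives 171 nM in this assay.
Compound 3 `Cn1nc2c(=O)n(CC3(O)CCN(Cc4ccc(-c5ccc[nH]5)cc4Cl)CC3)cnc2c1-c1ccc(CN)cc1` gives 193 nM in this assay.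

Compound 3 gives the largest of the three numbers, yet it sits alongside the other two: a 1.1-fold higher number from compound 1 to compound 3 (0.04 log units; within the scatter) and a 1.1-fold higher number from compound 2 to compound 3 (0.05 log units; within the scatter), both within the scatter. All three measured compounds share one core and differ only in the five-membered aromatic ring on the aromatic carbon that carries it.

Compound 4 `Cn1nc2c(=O)n(CC3(O)CCN(Cc4ccc(-c5ccc(C(=O)O)o5)cc4Cl)CC3)cnc2c1-c1ccc(CN)cc1` continues this series with the change (5-carboxyfuran-2-yl in place of 1H-pyrrol-2-yl on an aromatic carbon).

Every measured step bears on this change, since each exchanges the same five-membered ring at the same place: a 1.0-fold lower number from compound 1 to compound 2 (0.01 log units; within the scatter), a 1.1-fold higher number from compound 1 to compound 3 (0.04 log units; within the scatter) and a 1.1-fold higher number from compound 2 to compound 3 (0.05 log units; within the scatter). None of them left the scatter, although none introduced a carboxyl group, so the present change reaches a little further than any step seen. On that basis compound 4 is expected to show a 1.0-fold higher number from compound 3 to compound 4 (0.02 log units; within the scatter), no step beyond the scatter. The estimate for compound 4 in this assay is 200 nM, with a range from 80 nM to 500 nM.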

Compound 4, half-maximal inhibitory concentration: 753 nM
For compound 4 the middle estimate is 3.8-fold (0.58 log units) below the measured one; measured number above the stated range.
By their numbers in this assay, from the lowest: compounds 2, 1 and 3 (each within the scatter of the next); then compound 4.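

Among these compounds, the ring on this aromatic carbon, para to a large group, is not as free to change as the earlier compounds suggested: 5-carboxyfuran-2-yl is the first replacement to give a step beyond the scatter (a 3.9-fold higher number from compound 3 to compound 4 (0.59 log units; beyond the scatter)). The weakening is seen against all three earlier rings, as it also appears against furan-3-yl (a 4.3-fold higher number from compound 1 to compound 4 (0.63 log units; beyond the scatter)) and against the ring of compound 2 (a 4.4-fold higher number from compound 2 to compound 4 (0.64 log units; beyond the scatter)). Nothing available here explains the loss.

The compounds shown leave open whether the step belongs to the carboxylic acid itself or to the furan-2-yl attachment, as compound 4 differs from compound 1 in both. A plain furan-2-yl, a methyl ester or a primary carboxamide at this place would tell these apart.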